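Stretching One Arm of Compound 1 by a Double Bond

The source may hold more compounds than are shown below. What is called first, only, known or untested is meant among the compounds shown, and "the series" means these compounds.

Measured so far:
compound 1, `COC(=O)/C=C/c1cccc(N(Cc2ccc(-c3ccc(OC)cc3)cc2)C(=O)C2CCCCC2)c1`, 89 nM
compound 2, `COC(=O)/C=C/c1cccc(N(Cc2ccc(-c3ccc(OC)cc3)cc2)C(=O)C(C)C)c1`, 97 nM
compound 3, `COC(=O)/C=C/c1cccc(N(Cc2ccc(/C=C/C(=O)OC(C)(C)C)cc2)C(=O)c2ccccc2)c1`, 236 nM

All three were tested in an assay on isolated protein with Bile acid receptor (Homo sapiens) as the target; on this read-out lower numbers stand for an effect already at smaller amounts and higher numbers for an effect only at larger amounts of compound. Among them compound 1 gives the lowest number, 89 nM, with compound 2 at 97 nM and compound 3 at 236 nM. For the measured compounds named here, the only single-point step among them, a 1.1-fold higher number from compound 1 to compound 2 (0.04 log units; within the scatter), shows that swapping the group on the carbonyl carbon hardly matters here.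

Compound 4, `COC(=O)/C=C/c1cccc(N(Cc2ccc(/C=C/c3ccc(OC)cc3)cc2)C(=O)C2CCCCC2)c1`, has not yet been measured. It differs from compound 1 in one place: 2-(4-methoxyphenyl)ethenyl in place of 4-methoxyphenyl on an aromatic carbon. Going by the values given here, no measured step touches this arm of the molecule; compound 3 carries a different group there together with a different carbonyl substituent, so its higher number cannot be assigned to either change alone. The expectation therefore rests on the closeness of compound 1 and compound 2 and on compound 3 being only modestly weaker. For compound 4 a step of a 1.5-fold higher number from compound 1 to compound 4 (0.16 log units; within the scatter) is expected, which is within the scatter. The estimate for compound 4 is 130 nM, with a range from 50 nM to 350 nM.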

Compound 4, half-maximal effective concentration: 208 nM
Estimate against measurement, compound 4: 1.6-fold (0.20 log units) below; the measured number falls inside the stated range.
By their numbers in this assay, from the lowest: compounds 1 and 2 (each within the scatter of the next); then compounds 4 and 3 (each within the scatter of the next).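

In this assay, for the compounds shown here, lengthening this arm gives a 2.3-fold higher number from compound 1 to compound 4 (0.37 log units; beyond the scatter), the first measured single change at this position. The size of this step stands apart from a 1.1-fold higher number from compound 1 to compound 2 (0.04 log units; within the scatter), the change on the carbonyl carbon, so the group on the aromatic carbon para to a large group can shift the number where that swap did not. No measurement here explains why 2-(4-methoxyphenyl)ethenyl gives a higher number than 4-methoxyphenyl.

The compounds shown leave open whether the ethenyl link itself or the greater length accounts for the step, which 2-(4-methoxyphenyl)ethyl could help separate. They also leave open how a carboxylic acid or an amine in place of the methoxy group would read, and whether the step would persist with isopropyl instead of cyclohexyl on the carbonyl carbon.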